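A few compounds are considered here, and "the series" means these few. Any claim that something is new, unique, unknown or untested is made for them only; others in the source may bear on it.

Working notes on the series. Compound 1 has the structure `Oc1ccc(-c2cc(-c3ccccn3)nc(-c3ccccc3Cl)c2)cc1`, compound 2 the structure `Oc1ccc(-c2cc(-c3ccccc3)nc(-c3ccccc3Cl)c2)cc1` and compound 3 the structure `Oc1ccc(-c2cc(-c3ccncc3)nc(-c3ccccc3Cl)c2)cc1`; the three share one core and differ in a single aryl group. In an assay on isolated protein for inhibition of DNA topoisomerase 1 (Homo sapiens), with a stated time of 30 min, tested at 100 uM (on this read-out lower numbers stand for a weaker effect and higher numbers for a stronger effect at the one concentration tested), compound 1 gives 5.2%, compound 2 gives 13.6% and compound 3 gives 9.9%. Every step between them stays within the scatter: a number 8.4 percentage points higher from compound 1 to compound 2 (within the scatter), a number 4.7 percentage points higher from compound 1 to compound 3 (within the scatter) and a number 3.7 percentage points lower from compound 2 to compound 3 (within the scatter). On these numbers compound 3 stands second highest of the three, nearest to compound 2 and furthest from compound 1, but neither gap is beyond the scatter, so the three are not separable.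

Compound 4, with the structure `Oc1ccc(-c2cc(-c3ccncc3)nc(-c3cccc(Cl)c3)c2)cc1`, differs from compound 3 as follows: 3-chlorophenyl in place of 2-chlorophenyl on an aromatic carbon. Going by the values given here, no measured step touches this group; each of the three measured steps exchanges a different aryl group, and each of them remained within the scatter. There is thus no direct guide for this change in this assay, only the observation that exchanging one aryl group for another has so far not moved the read-out beyond the scatter. The step expected is therefore a number 0.1 percentage points higher from compound 3 to compound 4 (within the scatter), none beyond the scatter. Compound 4 is estimated at 10%, with a range from 0% to 22%.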

Compound 4, a percentage reported as inhibition, at one concentration (the size of the read-out at that concentration, not a potency): 29.2%
The estimate for compound 4 lay 19.2 percentage points below the measured number, outside the stated range (above it).
By their numbers in this assay, from the lowest: compounds 1, 3 and 2 (each within the scatter of the next); then compound 4.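

In this assay, going by these compounds alone, exchanging 2-chlorophenyl for 3-chlorophenyl on the aromatic carbon next to the ring nitrogen gives a number 19.3 percentage points higher from compound 3 to compound 4 (beyond the scatter), the first step to clear the scatter. The two groups match in heavy atoms, ring type and hydrogen-bond counts, so the read-out at this position responds to how the same atoms are joined, whereas the exchanges among phenyl, pyridin-2-yl and pyridin-4-yl in the other aryl group all stayed within the scatter. Nothing available on this series accounts for the difference between the two chlorophenyl groups.

The compounds shown leave open whether the effect of 3-chlorophenyl carries over when phenyl or pyridin-2-yl replaces pyridin-4-yl, since this comparison rests on a single pair of compounds. Also open, as far as these compounds go, is how this position responds to other groups, such as 4-chlorophenyl, unsubstituted phenyl or 3-methoxyphenyl, and whether the step at the one concentration tested reflects a real difference in potency.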